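Cyclohexyl for sec-butyl on an amine in curcumin-like chains

The source may report more compounds than this note shows. Statements on the series, on what has been measured and on what is new or still open speak of the compounds shown alone.

Compound 3 `CCC(C)NC(=C\C(=O)/C=C/c1ccc(OC(C)=O)c(OC)c1)/C=C/c1ccc(OC(C)=O)c(OC)c1` is measured in a functional assay on CHO-K1 cells (Cricetulus griseus) for inhibition, read by MTT assay, with a stated time of 72 h (a higher number here means a weaker inhibitor, a lower number a stronger inhibitor), and gives > 25000 nM, which is a limit of the assay rather than a number. Compound 1 `COc1cc(/C=C/C(=O)/C=C(/C=C/c2ccc(OC(C)=O)c(OC)c2)NC2CCCCC2)ccc1OC(C)=O` gives 10100 nM in this assay. The change between them, (cyclohexyl in place of sec-butyl on an amine nitrogen), brings an at least 2.4-fold lower number from compound 3 to compound 1 (0.39 log units; beyond the scatter). Compound 2 `CCC(C)NC(=C\C(=O)/C=C/c1ccc(O)cc1)/C=C/c1ccc(O)cc1` gives 13100 nM in this assay, which sits within the scatter of compound 1; the difference between the cores of compound 2 and compound 3 is not broken down here. Compound 4 `O=C(/C=C(/C=C/c1ccc(O)cc1)NC1CCCCC1)/C=C/c1ccc(O)cc1` is not yet measured and differs from compound 2 by the same change, (cyclohexyl in place of sec-butyl on an amine nitrogen). A step of a 1.9-fold lower number from compound 2 to compound 4 (0.27 log units; within the scatter) is expected in this assay, resting on the measured step from compound 3 to compound 1, an at least 2.4-fold lower number from compound 3 to compound 1 (0.39 log units; beyond the scatter). Compound 4 is therefore estimated at 7000 nM in this assay, between 3000 nM and 15000 nM.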

Compound 4, half-maximal inhibitory concentration: 9200 nM
Beside the measured number, compound 4's estimate is 1.3-fold (0.12 log units) below it; the range from low to high includes it.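

On the core of compound 2, cyclohexyl in place of sec-butyl on an amine nitrogen brings in this assay a 1.4-fold lower number from compound 2 to compound 4 (0.15 log units; within the scatter), a step too small to separate the two compounds. Set beside the earlier step, this neither shows that the change carries over from one core to the other with the same size nor shows that its size depends on the core: the same change on two cores in this assay, an at least 2.4-fold lower number (0.39 log units; beyond the scatter) from compound 3 to compound 1 and a 1.4-fold lower number (0.15 log units; within the scatter) from compound 2 to compound 4; the limit leaves it open whether they differ. The value of compound 3 is a limit of the assay and not a number: the limit of > 25000 nM in this assay, at which 1 of the 4 values shown sits.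

The compounds shown leave open how other groups on this amine nitrogen, such as cyclopentyl or benzyl, would compare with sec-butyl and cyclohexyl. They also leave open whether the change would give a step beyond the scatter on a further core.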